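The source may report more compounds than this note shows. Statements on the series, on what has been measured and on what is new or still open speak of the compounds shown alone.

Of the compounds shown here, three have been tested in a functional assay on A2780 cells (Homo sapiens) for cytotoxicity, read by MTT assay, with a stated time of 4 days (a higher number here means a weaker inhibitor, a lower number a stronger inhibitor), and each came back at a limit rather than as a number. Compound 1 `COc1cc(C(=O)O[C@@H]2C[C@](C)(O)[C@H]3[C@H](O[C@@H]4O[C@H](CO)[C@@H](O)[C@H](O)[C@H]4O)OC=C[C@H]32)ccc1O[C@@H]1O[C@H](CO)[C@@H](O)[C@H](O)[C@H]1O` gives > 10000 nM in this assay, which is a limit. Compound 2 `CC(/C=C/[C@@]1(O)C(C)(C)CCC[C@@]1(C)O)=C\C(=O)O[C@@H]1C[C@](C)(O)[C@H]2[C@H](O[C@@H]3O[C@H](CO)[C@@H](O)[C@H](O)[C@H]3O)OC=C[C@H]21` gives > 10000 nM in this assay, again a limit. Compound 3 `CC(/C=C/[C@@]1(O)C(C)(C)C[C@H](O)C[C@@]1(C)O)=C\C(=O)O[C@@H]1C[C@](C)(O)[C@H]2[C@H](O[C@@H]3O[C@H](CO)[C@@H](O)[C@H](O)[C@H]3O)OC=C[C@H]21` gives > 10000 nM in this assay, also a limit. So compound 3 stands where every measured compound stands: at the limit, with no number of its own. Among the measured compounds shown here, the one step between measured compounds that differ in a single place, a step that the two limits leave unreadable from compound 2 to compound 3, is unreadable in size because both of its values fall at the limit of > 10000 nM in this assay, at which 3 of the 3 values shown sit.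

Compound 4 `CC(/C=C/[C@@]1(O)C(C)(C)CC[C@@H](O)[C@@]1(C)O)=C\C(=O)O[C@@H]1C[C@](C)(O)[C@H]2[C@H](O[C@@H]3O[C@H](CO)[C@@H](O)[C@H](O)[C@H]3O)OC=C[C@H]21` differs from compound 3 only in the saturated ring that carries the hydroxy groups: 1,2,3-trihydroxy-2,6,6-trimethylcyclohexyl in place of 1,2,4-trihydroxy-2,6,6-trimethylcyclohexyl on a double-bonded chain carbon bound to a double-bonded chain carbon. For the measured compounds named here, the step that the two limits leave unreadable from compound 2 to compound 3, which added a hydroxy on a saturated ring carbon, gave no readable size, so no measured step speaks to the size or direction of this change. With all three measured compounds at the limit, compound 4 is expected to stay there too, and the step that the limit leaves unreadable from compound 3 to compound 4 is expected to lie within the scatter. Compound 4 is therefore estimated at 15000 nM, within 5000 nM to 50000 nM, with a limit rather than a number the likely outcome in this assay.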

Compound 4, half-maximal inhibitory concentration: > 10000 nM
Compound 4 gave a limit, no number (the forecaster's own chance of this, stated with the estimate: 85%); the middle value lies beyond the limit too.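

The steps from compound 3 to compound 4 and from compound 2 to compound 4 cannot be read in size, because both values in each pair sit at a limit: the limit of > 10000 nM in this assay, at which 4 of the 4 values shown sit. The compounds shown leave open how far apart these compounds truly lie in this assay, and whether any change on the shared core would give a measurable number there.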